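The source may hold more compounds than are shown below. What is called first, only, known or untested is meant among the compounds shown, and "the series" means these compounds.

Measured compounds:
compound 1 `COc1cccc(/C=N/NC(=O)c2ccc(C)cc2O)c1` — 672000 nM
compound 2 `Cc1ccc(C(=O)N/N=C/c2cc(Cl)cc(Cl)c2O)c(O)c1` — 708000 nM
compound 3 `Cc1ccc(C(=O)N/N=C/c2cc(Cl)ccc2O)c(O)c1` — 560000 nM

In an ADME assay on cells (Mus musculus, strain BALB/C) for cytotoxicity, read by MTT assay, with a stated time of 24 h (a lower number here means that less compound is tolerated, a higher number that more compound is tolerated), compound 1 gives 672000 nM. Compound 2 gives 708000 nM and compound 3 gives 560000 nM, and both of these lie within the scatter of the number for compound 1, so the three measured compounds cannot be told apart in this assay.

Compound 4 `Cc1ccc(C(=O)N/N=C/c2cccc(F)c2)c(O)c1` is not yet measured. It differs from compound 1 in one place: fluoro in place of methoxy on an aromatic carbon. Among the measured compounds shown here, the only measured step that changes a substituent on this aromatic ring is a 1.3-fold lower number from compound 2 to compound 3 (0.10 log units; within the scatter), which did not move the number beyond the scatter. For the measured compounds named here, that step concerns a different substituent and a different position, so it bears only loosely on the present change, but nothing among the measured compounds suggests that any substituent on this ring shifts the number in this assay.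

Compound 4 is therefore expected to give 650000 nM, with a range from 330000 nM to 1300000 nM, which would be a step of a 1.0-fold lower number from compound 1 to compound 4 (0.01 log units; within the scatter) and no change beyond the scatter.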

Compound 4, half-maximal cytotoxic concentration: 166000 nM
Estimate against measurement, compound 4: 3.9-fold (0.59 log units) above; measured number outside the range, below it.
By their numbers in this assay, from the lowest: compound 4; then compounds 3, 1 and 2 (each within the scatter of the next).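

In this assay, putting fluoro in place of methoxy on this aromatic carbon, meta to a large group, gives a 4.0-fold lower number from compound 1 to compound 4 (0.61 log units; beyond the scatter) and so moves the number beyond the scatter: less compound is tolerated with fluoro here than with methoxy. Among the compounds shown here, the only earlier step, a 1.3-fold lower number from compound 2 to compound 3 (0.10 log units; within the scatter) and a swap of chloro for hydrogen at another place, had stayed within the scatter, so the compounds now show that a single substituent change can matter in this assay. No measurement offered here accounts for this step.

The compounds shown cannot tell whether the lower number belongs to the arrival of fluoro or to the loss of methoxy, and hydrogen, chloro or an amine at this place could separate the two. On these data alone, whether the same swap elsewhere on the ring would move the number also remains open.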